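Hydrazone aryl swap: dihydroxyphenyl analogue of compound 3

The compounds below may be only part of what the source reports. "The series", "measured", "known", "first", "only" and "open" are said of these compounds alone.

Among the compounds with values here, compound 3 `CN(C)CCn1cnnc1-c1cc(Oc2ccc(NC(=O)N/N=C/c3c(Cl)cccc3Cl)cc2F)ccn1` gives 1410 nM in a functional assay on A549 cells (Homo sapiens) for cytotoxicity, read by MTT assay, with a stated time of 72 h (on this read-out lower numbers stand for stronger inhibition and higher numbers for weaker inhibition), and stands second highest of the three numbers so far. Compound 1 `CN(C)CCn1cnnc1-c1cc(Oc2ccc(NC(=O)N/N=C/c3ccc(F)cc3Cl)cc2F)ccn1` gives 1120 nM in this assay, and compound 2 `CN(C)CCn1cnnc1-c1cc(Oc2ccc(NC(=O)N/N=C/c3ccc(F)cc3)cc2F)ccn1` gives 1790 nM; the steps of a 1.3-fold higher number from compound 1 to compound 3 (0.10 log units; within the scatter) and a 1.3-fold lower number from compound 2 to compound 3 (0.10 log units; within the scatter) both lie within the scatter, so the three compounds are not separated by this read-out.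

Compound 4 `CN(C)CCn1cnnc1-c1cc(Oc2ccc(NC(=O)N/N=C/c3ccc(O)cc3O)cc2F)ccn1` differs from compound 3 only on the aryl group attached to the carbon with a double bond to nitrogen: 2,4-dihydroxyphenyl in place of 2,6-dichlorophenyl on a carbon with a double bond to nitrogen

All measured steps vary this same aryl group. The step of a 1.6-fold higher number from compound 1 to compound 2 (0.20 log units; within the scatter) and the steps of a 1.3-fold higher number from compound 1 to compound 3 (0.10 log units; within the scatter) and a 1.3-fold lower number from compound 2 to compound 3 (0.10 log units; within the scatter) are each within the scatter, so changes here have so far moved the number little. Within the data shown here, none of the measured compounds carries a hydroxyl on this ring, so the hydroxyls bring no precedent. For compound 4 the expected step is a 1.1-fold higher number from compound 3 to compound 4 (0.03 log units; within the scatter), a change not beyond the scatter. Compound 4 is estimated at 1500 nM in this assay, with a range from 600 nM to 4000 nM.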

Compound 4, half-maximal inhibitory concentration: 12700 nM
Beside the measured number, compound 4's estimate is 8.5-fold (0.93 log units) below it; measured number outside the range, above it.
By their numbers in this assay, from the lowest: compounds 1, 3 and 2 (each within the scatter of the next); then compound 4.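

In this assay the aryl group on the carbon with a double bond to nitrogen is not indifferent to every change: compounds 1, 2 and 3 stay within the scatter of one another, whereas 2,4-dihydroxyphenyl gives a 9.0-fold higher number from compound 3 to compound 4 (0.95 log units; beyond the scatter) and a 7.1-fold higher number from compound 2 to compound 4 (0.85 log units; beyond the scatter) and an 11-fold higher number from compound 1 to compound 4 (1.05 log units; beyond the scatter) on this position. Compound 4 is the only compound shown with hydroxyls on this ring, and the only one that stands apart from the rest, so a single example carries this reading. No measurement at hand bears on why the number rises with this change.

Open, going by these compounds, is whether one hydroxyl on the ring would give a number near that of compound 4 or near those of the halogen-bearing compounds. Also open, on these data alone, is where a ring with methoxy groups in place of the hydroxyls would fall.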